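Furan for hydroxyphenyl at the diaryl position

The source may report more compounds than this note shows. Statements on the series, on what has been measured and on what is new or still open speak of the compounds shown alone.

Within the data shown here, compound 2 `Nc1nc(-c2cccc(O)c2)nc2sc(-c3ccccc3)nc12` gives 190 nM in an assay on CHO cells for displacement of a labelled ligand from adenosine receptor A3 (Homo sapiens), read by scintillation counting, with a stated time of 3 h (a lower number here means a stronger inhibitor, a higher number a weaker inhibitor), the highest of the two numbers so far; compound 1 `COc1ccc(-c2nc(N)c3nc(-c4ccccc4)sc3n2)cc1` gives 46.7 nM. Among the measured compounds shown here, the one measured step is a 4.1-fold higher number from compound 1 to compound 2 (0.61 log units; beyond the scatter), a modest rise. Compound 3 `Cc1ccc(-c2nc(N)c3nc(-c4ccccc4)sc3n2)o1` carries 5-methylfuran-2-yl in place of 3-hydroxyphenyl on an aromatic carbon. The measured step bears on the same place and shows the 3-hydroxyphenyl of compound 2 sitting above compound 1; replacing it is expected to move the number back toward compound 1, though the entering five-membered ring is new to the series. Compound 3 is expected near 80 nM, with a range of 25 nM to 300 nM. That means an expected step of a 2.4-fold lower number from compound 2 to compound 3 (0.38 log units; beyond the scatter).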

Compound 3, inhibition constant: 24.9 nM
Compound 3: the middle estimate sits 3.2-fold (0.51 log units) above what was measured, outside the stated range (below it).
By their numbers in this assay, from the lowest: compounds 3 and 1 (each within the scatter of the next); then compound 2.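

This position accepts a five-membered aromatic ring as well as a six-membered one: 5-methylfuran-2-yl in place of 3-hydroxyphenyl gives a 7.6-fold lower number from compound 2 to compound 3 (0.88 log units; beyond the scatter). Set against the 4-methoxyphenyl group, the same ring gives a 1.9-fold lower number from compound 1 to compound 3 (0.27 log units; within the scatter), so the two groups cannot be told apart here. Nothing available explains either step.

Open, from the compounds shown here alone, is what the methyl group contributes, which a plain furan-2-yl or a thiophene would test. Also open, going by these compounds, is how a ring carrying an amine or a carboxylic acid behaves at this position.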